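From Isopropyl to Neopentyl on a Carbonyl Carbon

This account rests on a few compounds, and the source may have more. Where it says the series, first, only, none or still open, it means among the compounds named here.

Of the compounds shown here, three sharing one core have been measured in a functional assay on K562 cells (Homo sapiens) for inhibition; on this read-out higher numbers stand for weaker inhibition and lower numbers for stronger inhibition. Compound 1 (`CCCCCC(=O)OC1C(C(O)CO)OC2OC(C)(C)OC21`) gives 1200000 nM, compound 2 (`CC(=O)OC1C(C(O)CO)OC2OC(C)(C)OC21`) gives 3800000 nM, and compound 3 (`CC(C)C(=O)OC1C(C(O)CO)OC2OC(C)(C)OC21`) gives 2500000 nM. Compound 3 thus stands level with compound 2, as a 1.5-fold lower number from compound 2 to compound 3 (0.18 log units; within the scatter) shows, and its number lies above that of compound 1, as a 2.1-fold higher number from compound 1 to compound 3 (0.32 log units; beyond the scatter) shows.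

The next compound is compound 4 (`CC(C)(C)CC(=O)OC1C(C(O)CO)OC2OC(C)(C)OC21`), which differs from compound 3 by neopentyl in place of isopropyl on a carbonyl carbon. The change places neopentyl in place of isopropyl on a carbonyl carbon. Going by the values given here, two measured steps bear on it. Exchanging pentyl for isopropyl gave the modest 2.1-fold higher number from compound 1 to compound 3 (0.32 log units; beyond the scatter), and the longer gap between the chains of the first two compounds gave the modest 3.2-fold higher number from compound 1 to compound 2 (0.50 log units; beyond the scatter). Neopentyl is not pentyl, so only part of that gain is expected to carry over. The expected change is small and lies toward a lower number, a 1.5-fold lower number from compound 3 to compound 4 (0.17 log units; within the scatter). In this assay, compound 4 is estimated at 1700000 nM, with an expected range from 900000 nM to 3200000 nM.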

Compound 4, half-maximal inhibitory concentration: 1200000 nM
Estimate against measurement, compound 4: 1.4-fold (0.15 log units) above; the range from low to high includes it.
By their numbers in this assay, from the lowest: compounds 1 and 4 (each within the scatter of the next); then compounds 3 and 2 (each within the scatter of the next).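

Moving from isopropyl to neopentyl on this carbonyl carbon strengthens inhibition (a 2.1-fold lower number from compound 3 to compound 4 (0.32 log units; beyond the scatter)), which shows that the position accepts a larger branched group without loss, and the same compound also stands clear of the acetate compound (a 3.2-fold lower number from compound 2 to compound 4 (0.50 log units; beyond the scatter)). Until now, only the straight chain of compound 1 had stood apart from compound 2 and compound 3, yet tert-butyl in place of butyl on the saturated chain carbon leaves the result level (no change at the digits printed from compound 1 to compound 4 (within the scatter)), so the branching at the chain end makes no readable difference here. Nothing available explains why the larger groups give lower numbers.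

On these data alone, it remains open whether a longer chain than pentyl would lower the number further in this assay. A chain ending in an amine or a carboxylic acid is also an open case at this position.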